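The source may hold more compounds than are shown below. What is called first, only, known or untested is meant among the compounds shown, and "the series" means these compounds.

Measured in a physicochemical assay for solubility, with a stated time of 3 days, at pH 2; on this read-out lower numbers stand for lower solubility and higher numbers for higher solubility:
- Compound 1 `NC(=O)c1ccc2[nH]c(-c3ccc(OCC4CCCN(Cc5ccccc5)C4)cc3)nc2c1`: > 400000 nM, a limit of the assay and not a number
- Compound 2 `NC(=O)c1ccc2[nH]c(-c3ccc(OCCC4CCN(Cc5ccccc5)CC4)cc3)nc2c1`: 110000 nM

Among these two compounds, only compound 2 has an actual number in this assay, at 110000 nM. It therefore serves as the sole numerical reference point for what follows, as the other result is a limit.

The next compound to be tested is compound 3 `COc1ccc(CN2CCC(CCOc3ccc(-c4nc5cc(C(N)=O)ccc5[nH]4)cc3)CC2)cc1`. It keeps the shared core and the chain of compound 2, and it differs in one place, with methoxy in place of hydrogen on an aromatic carbon, para to a large group, so that benzyl becomes 4-methoxybenzyl: methoxy in place of hydrogen on an aromatic carbon.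

For the measured compounds named here, no measured pair in this small set shows what such a change does in this assay. The expectation thus rests on compound 2 at 110000 nM and on the modest size of the change. No change beyond the usual scatter is expected, and the estimated step of a 1.2-fold lower number from compound 2 to compound 3 (0.09 log units; within the scatter) leans slightly downward. For compound 3 the estimated value is 90000 nM, with an expected range from 40000 nM to 200000 nM.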

Compound 3, solubility: > 400000 nM
Compound 3: a limit, no number; the forecaster's own chance of this, stated with the estimate: 5%; middle value at least 4.4-fold (0.64 log units) from the limit.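

In this assay, for the compounds shown here, the change from benzyl to 4-methoxybenzyl gives the first readable step at this position, an at least 3.6-fold higher number from compound 2 to compound 3 (0.56 log units; beyond the scatter). This shows that methoxy in place of hydrogen on an aromatic carbon, para to a large group, does not leave the read-out unchanged on this chain, and that the number moves upward. The result for compound 3 is a limit of the assay and not a number, so the step cannot be sized any more closely because the read-out ends there: the limit of > 400000 nM in this assay, at which 2 of the 3 values shown sit.

The compounds shown leave open whether another group at the same place, such as fluorine, hydroxyl, an amine or a carboxylic acid, would move the number in the same direction, and how much of the step depends on the methyl of the methoxy rather than on its oxygen. They also leave open whether methoxy at this place would give a step of this direction with a shorter or longer chain, or with the other ring attachment seen in compound 1.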